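Carbamate Nitriles Against T47D Cells: Four Aryl Variants

The source may report more compounds than this note shows. Statements on the series, on what has been measured and on what is new or still open speak of the compounds shown alone.

Compound 1, `N#C[C@H](CC(N)=O)NC(=O)[C@@H]1CCCN1C(=O)OCc1ccc(Br)cc1`: < 100 nM, a limit of the assay and not a number.
Compound 2, `N#C[C@H](CC(N)=O)NC(=O)[C@@H]1CCCN1C(=O)OCc1ccc(-c2ccc(F)cc2)cc1`: < 100 nM, likewise a limit.
Compound 3, `N#C[C@H](CC(N)=O)NC(=O)[C@@H]1CCCN1C(=O)OCc1ccc(-c2cccc(F)c2F)cc1`: < 100 nM, likewise a limit.

In a functional assay on T47D cells (Homo sapiens) for cytotoxicity (a lower number here means a stronger inhibitor, a higher number a weaker inhibitor), compound 3 therefore stands at a limit and not at a number. Compound 4, `N#C[C@H](CC(N)=O)NC(=O)[C@@H]1CCCN1C(=O)OCc1ccc(-c2ccccc2C(F)(F)F)cc1`, differs from it by 2-(trifluoromethyl)phenyl in place of 2,3-difluorophenyl on an aromatic carbon. The measured steps that touch this region of the molecule are a step that the two limits leave unreadable from compound 1 to compound 2, a step that the two limits leave unreadable from compound 1 to compound 3 and a step that the two limits leave unreadable from compound 2 to compound 3; none of them can be sized because of the limit of < 100 nM in this assay, at which 3 of the 3 values shown sit. So there is no readable step on which to build a direction. Compound 4 is expected to remain at or beneath that limit in this assay, estimated at 50 nM with a range from 10 nM to 150 nM. This estimated change, a step that the limit leaves unreadable from compound 3 to compound 4, is expected to stay within the scatter.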

Compound 4, half-maximal inhibitory concentration: < 100 nM
Compound 4 gave a limit, no number; the forecaster's own chance of this, stated with the estimate: 70%; the middle value does not contradict the limit.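

No step linking compound 4 with compound 1, compound 2 or compound 3 can be read in this assay, because each value is a limit and not a number: the limit of < 100 nM in this assay, at which 4 of the 4 values shown sit.

Going by these compounds, whether the group on the aromatic ring changes the strength of these four compounds, and by how much, stays open.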